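The source may report more compounds than this note shows. Statements on the series, on what has been measured and on what is new or still open speak of the compounds shown alone.

In a functional assay on HCT-8 cells (Homo sapiens) for antiproliferative activity, read by MTT assay, with a stated time of 48 h (on this read-out lower numbers stand for stronger inhibition and higher numbers for weaker inhibition), compound 1 `COc1ccc(C(=O)c2ccc(OC)c3c2C=CC(C)(C)O3)c(NC(=O)CBr)c1` gives 4360 nM and so holds the higher of the two numbers available. Compound 2 `COc1ccc(C(=O)c2ccc3c(c2)C=CC(C)(C)O3)c(NC(=O)CO)c1` gives 250 nM in this assay and thus lies lower than compound 1 by more than the scatter. Compound 3 `CNCC(=O)Nc1cc(OC)ccc1C(=O)c1ccc(OC)c2c1C=CC(C)(C)O2` has not yet been measured. It departs from compound 1 at one place methylamino in place of bromo on a saturated chain carbon bound to a carbonyl carbon with methylamino in place of bromo on a saturated chain carbon bound to a carbonyl carbon. Within the data shown here, no measured step isolates this change, and compound 2 differs from compound 1 in more than this one place, so it offers only a loose guide. A moderate fall beyond the scatter is expected, toward compound 2 at 250 nM but short of it. The expected step is a 4.4-fold lower number from compound 1 to compound 3 (0.64 log units; beyond the scatter) in this estimate. For compound 3 the expected value is 1000 nM within an estimated range of 200 nM to 5000 nM in this assay once it is tested.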

Compound 3, half-maximal inhibitory concentration: 3460 nM
For compound 3 the middle estimate is 3.5-fold (0.54 log units) below the measured one; measured number inside the range.
By their numbers in this assay, from the lowest: compound 2; then compounds 3 and 1 (each within the scatter of the next).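

In this assay, putting methylamino in place of bromo on a saturated chain carbon bound to a carbonyl carbon gives a 1.3-fold lower number from compound 1 to compound 3 (0.10 log units; within the scatter). Among these compounds, this is the first direct reading of this position on the core of compound 1. It shows that this change, in which one heavy atom gives way to two and a hydrogen-bond donor and a hydrogen-bond acceptor enter, does not move the number beyond the usual scatter. Steps to compound 2 cannot be read, as it differs from compound 1 and compound 3 in more than one place.

From the compounds shown here alone, whether a dimethylamino group, a carboxylic acid or a longer chain at this place would move the number beyond the scatter remains open. Nothing at hand bears on why bromo and methylamino give such close numbers.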